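The source may report more compounds than this note shows. Statements on the series, on what has been measured and on what is new or still open speak of the compounds shown alone.

For the measured compounds named here, compound 2 `COc1cc(N(Cc2nc3ccccc3[nH]2)S(=O)(=O)c2ccc(C(C)(C)C)cc2)cc(OC)c1OC` gives 29800 nM in a functional assay on PC-3 cells (Homo sapiens) for inhibition, read by MTT assay, with a stated time of 48 h (a lower number here means a stronger inhibitor, a higher number a weaker inhibitor), and stands at the top of the two numbers measured so far, with compound 1 `COc1cc(N(Cc2nc3ccccc3[nH]2)S(=O)(=O)c2ccccc2)cc(OC)c1OC` at 25500 nM nearest and within the scatter. Compound 3 `COc1ccc(S(=O)(=O)N(Cc2nc3ccccc3[nH]2)c2cc(OC)c(OC)c(OC)c2)cc1OC` differs from compound 2 in one place: 3,4-dimethoxyphenyl in place of 4-(tert-butyl)phenyl on a sulfonyl sulfur. Going by the values given here, the only measured step that touches this part of the molecule is a 1.2-fold higher number from compound 1 to compound 2 (0.07 log units; within the scatter), a change that left the number essentially where it was. On that basis the step to compound 3 is expected to stay within the scatter, a 1.1-fold lower number from compound 2 to compound 3 (0.04 log units; within the scatter). Compound 3 is therefore estimated at 27000 nM, in the range 10000 nM to 80000 nM.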

Compound 3, half-maximal inhibitory concentration: 30400 nM
Estimate against measurement, compound 3: 1.1-fold (0.05 log units) below; the range from low to high includes it.
By their numbers in this assay, from the lowest: compounds 1, 2 and 3 (each within the scatter of the next).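

Measured by this assay, 3,4-dimethoxyphenyl on the sulfonyl sulfur gives a 1.0-fold higher number from compound 2 to compound 3 (0.01 log units; within the scatter) against 4-(tert-butyl)phenyl and a 1.2-fold higher number from compound 1 to compound 3 (0.08 log units; within the scatter) against phenyl in the same place. Oxygen-bearing methoxy groups, absent from the earlier compounds, therefore leave the number within the scatter, just as the tert-butyl group did. No supporting data are available to explain this lack of change. The compounds shown leave open whether an amine or a carboxylic acid on this ring would move the number, and whether changes elsewhere on the shared core would matter more.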